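This account rests on a few compounds, and the source may have more. Where it says the series, first, only, none or still open, it means among the compounds named here.

Compound 1 `CC(C)(C)NCc1c(C(=O)O)nn(-c2ccccc2)c1-c1ccc(Cl)cc1`: > 652000 nM
Compound 2 `CC(C)(C)NCc1c(C(=O)O)nn(-c2ccccc2)c1-c1ccc([N+](=O)[O-])cc1`: > 634000 nM

In a functional assay on MCF7 cells (Homo sapiens) for inhibition, read by sulforhodamine B assay, with a stated time of 48 h (on this read-out lower numbers stand for stronger inhibition of growth and higher numbers for weaker inhibition of growth), compound 1 gives > 652000 nM, which is a limit and not a number. Compound 2 gives > 634000 nM, also a limit. Among the measured compounds shown here, the only measured step is a step that the two limits leave unreadable from compound 1 to compound 2, so it offers no size to carry over. Compound 3 `CC(C)(C)NCc1c(C(=O)O)nn(-c2ccc(Cl)cc2)c1-c1ccc(Cl)cc1` differs from compound 1 by chloro in place of hydrogen on an aromatic carbon, para to a large group. With no readable step as a guide, no shift beyond the scatter is expected in this assay. The expected step is an at least 1.0-fold lower number from compound 1 to compound 3 (0.03 log units; that floor lies within the scatter). Compound 3 is estimated at 600000 nM, with an expected range from 250000 nM to 900000 nM.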

Compound 3, concentration for 50% growth inhibition: 246000 nM
Compound 3: the middle estimate sits 2.4-fold (0.39 log units) above what was measured; measured number below the stated range.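

In this assay, among the compounds shown here, changing phenyl to 4-chlorophenyl gives an at least 2.6-fold lower number from compound 1 to compound 3 (0.42 log units; beyond the scatter), the first step with a readable size. This shows that a single chloro at this position can move the read-out, whereas the earlier change on the other aromatic ring left only two limits to compare. The size of this step is a floor, since compound 1 has a limit and not a number: the limit of > 652000 nM in this assay, at which 1 of the 3 values shown sits.

Going by these compounds, whether fluoro or methoxy at this same position would lower the number as much remains open. So does whether the step would hold with an amide in place of the carboxylic acid.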